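The source may report more compounds than this note shows. Statements on the series, on what has been measured and on what is new or still open speak of the compounds shown alone.

Two compounds of this study were tested in a functional assay on cells (Panel leukemia (Carcinoma cell lines), Homo sapiens) for inhibition; on this read-out lower numbers stand for stronger inhibition of growth and higher numbers for weaker inhibition of growth. Compound 1 `Cc1ccc(/C=C2\CN(C)CC3=C2N=C(S)NC3c2ccc(C)cc2)cc1` gives 62300 nM in this assay. Compound 2 `CN1C/C(=C\c2cccs2)C2=NN(C)C(c3cccs3)C2C1` gives 87800 nM in this assay, the higher of the two numbers, though the gap to compound 1 lies within the usual scatter, so the two cannot be ranked against each other.

Compound 3 `CN1C/C(=C\c2cccs2)C2=NN(c3ccccc3)C(c3cccs3)C2C1` has not yet been measured. It differs from compound 2 in one place: phenyl in place of methyl on an amine nitrogen in a ring. The change sits on an amine nitrogen in a ring of a five-membered non-aromatic ring with 2 nitrogen, part of a fused or bridged system of two rings.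

Among the measured compounds shown here, no measured pair in this set shows what such a change does, so the expectation for compound 3 rests on compound 2 alone. The step from compound 2 to compound 3 is expected to be a 1.2-fold lower number from compound 2 to compound 3 (0.07 log units; within the scatter), that is, nothing beyond the scatter. Compound 3 is therefore estimated at 75000 nM in this assay, with a range from 25000 nM to 200000 nM.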

Compound 3, concentration for total growth inhibition: 52200 nM
Beside the measured number, compound 3's estimate is 1.4-fold (0.16 log units) above it; the range from low to high includes it.
By their numbers in this assay, from the lowest: compounds 3, 1 and 2 (each within the scatter of the next).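

In this assay, phenyl in place of methyl on this amine nitrogen in a ring gives a 1.7-fold lower number from compound 2 to compound 3 (0.23 log units; within the scatter), so a six-membered aromatic ring of six carbons can stand at this position with no shift that can be told from the scatter. Among the compounds shown here, the earlier compounds held no pair differing in one place, so this step is the only direct reading of a change here. Nothing measured accounts for the size of this step, and no cause can be given for it.

The compounds shown leave open whether another group on this nitrogen, such as benzyl, a longer alkyl chain or a chain ending in a carboxylic acid, would move the number beyond the scatter. They also leave open whether the swap from methyl to phenyl reads the same with a furan-2-yl group in place of the thiophen-2-yl group.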